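Swapping trifluoromethyl for methoxy on compound 1

This account rests on a few compounds, and the source may have more. Where it says the series, first, only, none or still open, it means among the compounds named here.

Compound 1 `CN1CCC(Oc2ccc(N3C(=S)N(c4cnc(C#N)c(C(F)(F)F)c4)C(=O)C34CCC4)cc2)CC1`: 56%
Compound 2 `N#Cc1ncc(N2C(=O)C3(CCC3)N(c3ccc(CN4CCNCC4)cc3)C2=S)cc1C(F)(F)F`: 97%

In an ADME assay on the whole organism (Mus musculus, strain CD1) for pharmacokinetics, at a dose of 10 mg/kg by the oral route (on this read-out higher numbers stand for higher oral bioavailability and lower numbers for lower oral bioavailability), compound 1 holds the lower of the two numbers. Compound 3 `COc1cc(N2C(=O)C3(CCC3)N(c3ccc(OC4CCN(C)CC4)cc3)C2=S)cnc1C#N` differs from compound 1 in one group, with methoxy in place of trifluoromethyl on an aromatic carbon. Within the data shown here, only one measured step exists, a number 41 percentage points higher from compound 1 to compound 2 (beyond the scatter). It is large, but it concerns a different change elsewhere in the molecule, so it shows only that this assay can move widely and gives no direction here. No step beyond the scatter is therefore expected, and the expected step is a number 6 percentage points lower from compound 1 to compound 3 (within the scatter). For compound 3 the estimate is 50%, with an expected range of 25% to 75%.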

Compound 3, oral bioavailability: 87%
Compound 3: middle estimate off by 37 percentage points, on the low side; the measured number lies above the stated range.
By their numbers in this assay, from the lowest: compound 1; then compounds 3 and 2 (each within the scatter of the next).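

In this assay, methoxy in place of trifluoromethyl gives a number 31 percentage points higher from compound 1 to compound 3 (beyond the scatter), so this aromatic carbon, ortho to a cyano group, also affects the read-out, not only the group changed between compound 1 and compound 2. Methoxy brings fewer heavy atoms and one hydrogen-bond acceptor, but a single swap cannot separate these differences. No measurement here explains the rise.

From the compounds shown here alone, whether an ethoxy group or an amine on this carbon would act like methoxy remains open. So does whether methoxy would have the same effect alongside the (piperazin-1-yl)methyl group of compound 2.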